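Notes on double bond configuration in a small series

The source may report more compounds than this note shows. Statements on the series, on what has been measured and on what is new or still open speak of the compounds shown alone.

Values in a functional assay for cytotoxicity, with Homo sapiens as the target; on this read-out lower numbers stand for stronger inhibition of growth and higher numbers for weaker inhibition of growth
- compound 1 `CCCCCCn1c(=O)oc2ccc(NCc3cc(O)ccc3O)cc2c1=O` gives 3200 nM
- compound 2 `Oc1ccc(O)c(CNc2ccc(O)c(/C=C\CCc3ccccc3)c2)c1` gives 19300 nM

Compound 2 carries the higher number of the two, and its gap from compound 1 (3200 nM) lies beyond the scatter. Compound 3 `Oc1ccc(O)c(CNc2ccc(O)c(/C=C/CCc3ccccc3)c2)c1` has the same atoms and bonds as compound 2 and differs only in configuration as drawn (the two compounds have the same atoms and bonds and differ only in configuration as drawn: 1 of 1 stereo elements differ; a double bond is drawn Z in compound 2 and E in compound 3). Going by the values given here, no measured pair shows what such a change does in this assay, so no step beyond the scatter is expected. The expected size is a 1.3-fold lower number from compound 2 to compound 3 (0.11 log units; within the scatter) (an estimate with little data behind it). The estimate for compound 3 is 15000 nM (expected range 6000 nM to 40000 nM).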

Compound 3, concentration for 50% growth inhibition: 30400 nM
Estimate against measurement, compound 3: 2.0-fold (0.31 log units) below, and the stated range covers the measured number.
By their numbers in this assay, from the lowest: compound 1; then compounds 2 and 3 (each within the scatter of the next).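

In this assay, going by these compounds alone, changing the double bond from Z to E gives a 1.6-fold higher number from compound 2 to compound 3 (0.20 log units; within the scatter), so the first reading of this change does not separate the two compounds. The comparison concerns stereochemistry alone: the fact that compounds 2 and 3 differ only in the configuration as drawn. At this position, the configuration as drawn therefore gives no measurable gain or loss on this read-out.

Open, going by these compounds, is whether an amide or a saturated carbon chain in place of the double bond would give a number beyond the scatter of compounds 2 and 3. Compound 1 differs from both in more than one place, so its value cannot be tied to any single feature.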